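The compounds below may be only part of what the source reports. "The series", "measured", "known", "first", "only" and "open" are said of these compounds alone.

Compound 1 `CCCCC[Se]c1nc([Se]CCCCC)c2ccccc2n1` reaches only the limit of a functional assay on HTB-54 cells (Homo sapiens) for cytotoxicity, read by MTT assay, with a stated time of 72 h (on this read-out higher numbers stand for weaker inhibition of growth and lower numbers for stronger inhibition of growth), giving > 100000 nM. Going by the values given here, compound 2 `CCCCCSc1nc(NCc2ccc([Se]C)cc2)c2ccccc2n1` gives 19800 nM in this assay, the only plain number among the two values shown. Compound 3 `CSc1nc(NCc2ccc([Se]C)cc2)c2ccccc2n1` differs from compound 2 by hydrogen in place of butyl on a saturated chain carbon bound to a sulfur. Among the compounds with values here, no step between measured compounds is available, so the size of this change cannot be read from the data; the expected step of a 1.3-fold higher number from compound 2 to compound 3 (0.10 log units; within the scatter) is small, no larger than the usual scatter, with a slight lean towards weaker inhibition. Compound 3 is therefore estimated at 25000 nM, with a range from 8000 nM to 80000 nM.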

Compound 3, concentration for 50% growth inhibition: 57000 nM
The estimate for compound 3 lay 2.3-fold (0.36 log units) below the measured number; the measured number falls inside the stated range.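

Cutting pentylsulfanyl down to methylsulfanyl gives the first readable step at this position in this assay: a 2.9-fold higher number from compound 2 to compound 3 (0.46 log units; beyond the scatter). The chain on the sulfur therefore matters in this pair, with the pentyl chain going along with the stronger inhibition of growth, though only modestly.

With only these two chain lengths shown, a propyl chain or an amine in this place could show whether the change is gradual or abrupt. Any further weakening would have little room to be read, since the assay has a ceiling: the limit of > 100000 nM in this assay, at which 1 of the 3 values shown sits.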